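Removing the methoxycarbonyl from the benzyl ether of compound 1

The source may hold more compounds than are shown below. What is called first, only, known or untested is meant among the compounds shown, and "the series" means these compounds.

Compound 1 `COC(=O)c1ccc(COc2ccc(CNC(=O)[C@@H]3CCC(=O)N3Cc3ccccc3)cc2)cc1` stands only at a limit in an assay on HEK293 cells for inhibition of Ataxin-2 (Mus musculus), read by fluorescence and Amplex Red; a higher number here means a weaker inhibitor, a lower number a stronger inhibitor: in this assay compound 1 gives > 5000 nM, which is a limit of the assay rather than a number. Compound 2 `NS(=O)(=O)c1ccc(COc2ccc(CNC(=O)[C@@H]3CCC(=O)N3Cc3ccc(F)cc3)cc2)cc1` also sits at a limit; in this assay compound 2 gives > 5000 nM, again a limit and not a number. Two of the three values shown are such limits (the limit of > 5000 nM in this assay, at which 2 of the 3 values shown sit). For the measured compounds named here, compound 3 `CC1(C)OB(c2ccc(COc3ccc(CNC(=O)[C@H]4CCC(=O)N4Cc4ccccc4)cc3)cc2)OC1(C)C`, which carries a different substituent on its benzyl ether and whose stereocentre is drawn the other way, gives 180 nM in this assay; it is the only measured number in the set and is not taken as a step from compound 1. Compound 4 `O=C(NCc1ccc(OCc2ccccc2)cc1)[C@@H]1CCC(=O)N1Cc1ccccc1` arises from compound 1 by hydrogen in place of methoxycarbonyl on an aromatic carbon. Going by the values given here, no measured step covers this change. With compound 1 at a limit, the step from compound 1 to compound 4 cannot be placed against the scatter; the estimated step is a number no higher from compound 1 to compound 4 (the limit leaves the size open), with a limit again the more likely outcome. Compound 4 is estimated at 5000 nM in this assay, expected to fall within 1000 nM to 20000 nM.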

Compound 4, half-maximal inhibitory concentration: > 5000 nM
Compound 4 gave a limit, no number; the forecaster's own chance of this, stated with the estimate: 60%; the middle value lies on the limit itself.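

The step between compound 1 and compound 4 cannot be read, because both stand at a limit in this assay: the limit of > 5000 nM in this assay, at which 3 of the 4 values shown sit.

The compounds shown leave open whether hydrogen in place of methoxycarbonyl alters inhibition at all, and whether the substituent or the stereocentre drawn the other way separates compound 3, at 180 nM, from the rest.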